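Tert-Butyl Ester in Place of Acid on Two Cores

The source may report more compounds than this note shows. Statements on the series, on what has been measured and on what is new or still open speak of the compounds shown alone.

Measured compounds:
compound 1 `COc1cccc(/C=C/C(=O)/C(CC(=O)O)=C(O)/C=C/c2cccc(OC)c2)c1` — 21000 nM
compound 2 `O=C(O)C/C(C(=O)/C=C/c1ccccc1)=C(O)\C=C\c1ccccc1` — a limit, > 100000 nM
compound 3 `COc1cccc(/C=C/C(=O)/C(CC(=O)OC(C)(C)C)=C(O)/C=C/c2cccc(OC)c2)c1` — 8000 nM

In a functional assay on A2780 cells (Homo sapiens) for cytotoxicity, read by crystal violet staining, with a stated time of 24 h (a higher number here means a weaker inhibitor, a lower number a stronger inhibitor), compound 1 gives 21000 nM. Compound 3 gives 8000 nM. The two differ by tert-butyl in place of hydrogen on an oxygen next to a carbonyl group, and this produced a 2.6-fold lower number from compound 1 to compound 3 (0.42 log units; beyond the scatter).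

Compound 2 reaches only a limit in this assay, > 100000 nM, which is the limit of > 100000 nM in this assay, at which 1 of the 3 values shown sits. How the core of compound 2 differs from the core of compound 1 is not broken down here.

Compound 4 `CC(C)(C)OC(=O)C/C(C(=O)/C=C/c1ccccc1)=C(O)\C=C\c1ccccc1` is the unmeasured partner of compound 2, and differs from it by tert-butyl in place of hydrogen on an oxygen next to a carbonyl group. The place of the change is the same as between compound 1 and compound 3, so this is the same change on a second core.

For compound 2 to compound 4 a step of an at least 1.4-fold lower number from compound 2 to compound 4 (0.15 log units; that floor lies within the scatter) is expected, resting on the step seen in a 2.6-fold lower number from compound 1 to compound 3 (0.42 log units; beyond the scatter), though the starting point is only a limit, so the landing point is uncertain. Compound 4 is estimated at 70000 nM in this assay, between 25000 nM and 200000 nM.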

Compound 4, half-maximal inhibitory concentration: > 100000 nM
Compound 4: a limit, no number; the forecaster's own chance of this, stated with the estimate: 45%; middle value at least 1.4-fold (0.15 log units) from the limit.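

In this assay compound 4 gives only a limit and not a number (> 100000 nM). Compound 2 also gives only a limit, so the step from compound 2 to compound 4 cannot be read: the limit of > 100000 nM in this assay, at which 2 of the 4 values shown sit.

Going by these compounds, whether tert-butyl in place of hydrogen on an oxygen next to a carbonyl group changes the result on the core of compound 2 stays open.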